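This account rests on a few compounds, and the source may have more. Where it says the series, first, only, none or still open, it means among the compounds named here.

In a functional assay on HepG2 cells (Homo sapiens) for inhibition, read by MTT assay, with a stated time of 48 h (on this read-out lower numbers stand for stronger inhibition and higher numbers for weaker inhibition), compound 1 (`CC(=O)O[C@@H]1C[C@@H](OC(=O)c2ccccc2)/C(C)=C/[C@H]2[C@@H](OC(=O)c3ccccc3)[C@@H](C)[C@H](O)[C@]2(OC(C)=O)[C@H](O)[C@](C)(O)/C=C/C1(C)C`) gives > 150000 nM as a limit and not a number. Compound 2 (`CC(=O)O[C@@H]1C[C@@H](OC(=O)c2ccccc2)/C(C)=C/[C@H]2[C@@H](OC(=O)c3ccccc3)[C@@H](C)[C@H](OC(=O)c3cccs3)[C@]2(OC(C)=O)[C@H](O)[C@](C)(O)/C=C/C1(C)C`) gives > 150000 nM and this too is only a limit. Going by the values given here, the one measured step is a step that the two limits leave unreadable from compound 1 to compound 2 and offers no size to carry forward. Compound 3 (`CC(=O)O[C@@H]1C[C@@H](OC(=O)c2ccccc2)/C(C)=C/[C@H]2[C@@H](OC(=O)c3ccccc3)[C@@H](C)[C@H](OC(=O)c3ccccc3)[C@]2(OC(C)=O)[C@H](O)[C@](C)(O)/C=C/C1(C)C`) has phenyl in place of thiophen-2-yl on a carbonyl carbon. Because of the limit of > 150000 nM in this assay, at which 2 of the 2 values shown sit, no step beyond the scatter is expected in this assay and no direction can be expected. The expected move is a number no higher from compound 2 to compound 3 (the limit leaves the size open) on this reading. The estimate for compound 3 is 150000 nM within an expected range of 70000 nM to 200000 nM and a report as a limit is likely.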

Compound 3, half-maximal inhibitory concentration: > 150000 nM
Compound 3 was reported as a limit; the forecaster's own chance of this, stated with the estimate: 75%; the middle value sits exactly at the limit.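

Going by these compounds alone, no step among compound 1, compound 2 and compound 3 can be read, because all three values are the same limit: the limit of > 150000 nM in this assay, at which 3 of the 3 values shown sit. The compounds shown leave open whether hydrogen, (thiophen-2-yl)carbonyl and benzoyl on an oxygen on a saturated carbon differ at all in inhibition.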